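The source may hold more compounds than are shown below. What is called first, only, known or untested is meant among the compounds shown, and "the series" means these compounds.

Measured so far:
Compound 1, `Cc1c(OCCCCOCOc2ccc(C(=O)O)cc2)ccc(C(=O)CC2CCCC2)c1O`: 1910 nM
Compound 2, `CCCC(=O)c1ccc(OCCCCOc2ccc(C(=O)O)cc2C)c(C)c1O`: > 10000 nM, a limit of the assay

In an assay on HEK293 cells for positive allosteric modulation of metabotropic glutamate receptor 3 (Rattus norvegicus), read by thallium flux, with a stated time of 2.5 min (a lower number here means that less compound is needed, a higher number that more compound is needed for the effect), compound 2 reaches only the limit given by the limit of > 10000 nM in this assay, at which 1 of the 2 values shown sits, so no number stands for it. Compound 3, `Cc1cc(C(=O)O)ccc1OCCCCOc1ccc(C(=O)CC2CCCC2)c(O)c1C`, has not yet been measured. It differs from compound 2 by cyclopentyl in place of ethyl on a saturated chain carbon bound to a carbonyl carbon. Compound 1 carries the same (cyclopentylmethyl)carbonyl group and gives 1910 nM in this assay, which shows that this group is compatible with a measurable value. On that basis the step from the propylcarbonyl of compound 2 to the (cyclopentylmethyl)carbonyl of compound 3 is expected to go down, as the estimated step of an at least 4.0-fold lower number from compound 2 to compound 3 (0.60 log units; beyond the scatter) states. Compound 3 is therefore expected to land near 2500 nM, with a range from 800 nM to 10000 nM, while a limit instead of a number remains possible.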

Compound 3, half-maximal effective concentration: > 10000 nM
Compound 3: a limit, no number; the forecaster's own chance of this, stated with the estimate: 35%; at least 4.0-fold (0.60 log units) between middle value and limit.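

In this assay, the (cyclopentylmethyl)carbonyl group does not by itself secure a measurable value: compound 3 carries it and still stands at a limit of the assay, not at a number. The group is shared with compound 1, and 4-carboxy-2-methylphenyl in place of (4-carboxyphenoxy)methyl on an oxygen on a saturated carbon gives an at least 5.2-fold higher number from compound 1 to compound 3 (0.71 log units; beyond the scatter), so the measurable value of compound 1 depends on that part of the molecule. The effect of cyclopentyl in place of ethyl cannot be read, because compound 2 and compound 3 both stand at the limit: the limit of > 10000 nM in this assay, at which 2 of the 3 values shown sit.

As far as these compounds go, what cyclopentyl does on a saturated chain carbon bound to a carbonyl carbon when the rest of the molecule is that of compound 1 remains open. So does whether an amine or a cyclohexyl group in that place would give a number.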